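The compounds below may be only part of what the source reports. "The series", "measured", "known", "first", "only" and "open" are said of these compounds alone.

Measured so far in a functional assay on HeLa cells (Homo sapiens) for antiproliferative activity, read by CCK-8 assay, with a stated time of 72 h; on this read-out lower numbers stand for stronger inhibition of growth and higher numbers for weaker inhibition of growth:
compound 1 `CCC1C(=O)N(C)c2cnc(-n3ccc4cc(C(=O)NC)ccc43)nc2N1c1ccn(C)n1` gives 6330 nM 
compound 2 `CC[C@@H]1C(=O)N(C)c2cnc(-n3ccc4ccccc43)nc2N1C1CCCC1` gives 33900 nM 
compound 3 `CC[C@@H]1C(=O)N(C)c2cnc(-n3ccc4cc(C(=O)NCC(C)C)ccc43)nc2N1C1CCCC1` gives 3280 nM 

On these numbers compound 1 cannot be separated from compound 3, since the two lie within the scatter of each other. Compound 2 carries the highest number, and its gap to compound 1 lies beyond the scatter.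

Compound 4 `CCC1C(=O)N(C)c2cnc(-n3ccc4cc(C(=O)NCC(C)C)ccc43)nc2N1c1ccn(C)n1` keeps the core of compound 1 and alters only the amide side chain: isopropyl in place of hydrogen on a saturated chain carbon bound to an amide-type nitrogen turns methylcarbamoyl into isobutylcarbamoyl.

Within the data shown here, one measured step bears on this, a 10-fold lower number from compound 2 to compound 3 (1.01 log units; beyond the scatter), and it is large. That step, however, sets isobutylcarbamoyl against hydrogen, on compounds that also differ elsewhere from compound 1. Among the measured compounds shown here, it does not compare isobutyl with methyl, and no measured pair does so on a shared background. Compound 1 at 6330 nM and compound 3 at 3280 nM carry the two amides on different backgrounds and stay within the scatter, so a large step is not expected here.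

For compound 4 the expected change is a 1.6-fold lower number from compound 1 to compound 4 (0.20 log units; within the scatter) and would be a small move to a lower number, not one beyond the scatter. Compound 4 is estimated at 4000 nM as a central value, with an expected range from 1400 nM to 11000 nM in this estimate.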

Compound 4, concentration for 50% growth inhibition: 4970 nM
Compound 4: the middle estimate sits 1.2-fold (0.09 log units) below what was measured; the measured number falls inside the stated range.
By their numbers in this assay, from the lowest: compounds 3, 4 and 1 (each within the scatter of the next); then compound 2.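

Working notes on the amide side chain. In this assay, among these compounds, the two amides now meet on one background for the first time, and the result is a 1.3-fold lower number from compound 1 to compound 4 (0.11 log units; within the scatter) and so gives no separation between methylcarbamoyl and isobutylcarbamoyl on the core of compound 1. Added isopropyl on a saturated chain carbon bound to an amide-type nitrogen is thus accepted here without a readable change in growth inhibition. This is a different question from the one answered by a 10-fold lower number from compound 2 to compound 3 (1.01 log units; beyond the scatter) on a separate background, where isobutylcarbamoyl replaces hydrogen on an aromatic carbon. No measurement at hand offers an explanation for the flat result.

As far as these compounds go, whether the amide is needed at all on the core of compound 1 stays open, as the hydrogen comparison exists only on the background of compound 2 and compound 3. Also open, from the compounds shown here alone, is whether a carboxylic acid, an unsubstituted carboxamide or a longer chain ending in an amine in place of the isobutyl group would move the number beyond the scatter on either background.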